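Swapping the sulfur-linked side chain of compound 2 for propyl

A few compounds are considered here, and "the series" means these few. Any claim that something is new, unique, unknown or untested is made for them only; others in the source may bear on it.

Measured so far in an assay on HEK293 cells for inhibition of protein deacetylase HDAC6 (Homo sapiens); a lower number here means a stronger inhibitor, a higher number a weaker inhibitor:
compound 1, `CCSC(=S)SCC(=O)c1ccc(NC(=O)c2cnc3ccccc3c2)cc1`, gives 119 nM;
compound 2, `COCCSC(=S)SCC(=O)c1ccc(OC)cc1`, gives 2130 nM;
compound 3, `CCSC(=S)SCC(=O)c1cccc(S(=O)(=O)Nc2cccc(C(N)=O)c2)c1`, gives 181 nM.

Compound 2 stands at the highest of these three numbers, above both compound 1 and compound 3 by gaps beyond the usual scatter, so it is the weakest inhibitor of the set. Compound 4, `CCCC(=S)SCC(=O)c1ccc(OC)cc1`, has not yet been measured in this assay. It differs from compound 2 in one place: propyl in place of (2-methoxyethyl)sulfanyl on a thiocarbonyl carbon. For the measured compounds named here, no pair among the measured compounds shows what such a change does, so the expectation rests on compound 2 alone. Compound 4 is estimated to give 2500 nM, with a range from 800 nM to 8000 nM. This estimate means a step of a 1.2-fold higher number from compound 2 to compound 4 (0.07 log units; within the scatter), expected to stay within the scatter of repeated measurements.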

Compound 4, half-maximal inhibitory concentration: 110 nM
Compound 4: middle estimate off by 23-fold (1.36 log units), on the high side; the measured number lies below the stated range.
By their numbers in this assay, from the lowest: compounds 4, 1 and 3 (each within the scatter of the next); then compound 2.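

In this assay the group on this thiocarbonyl carbon proves to have a strong hold on the result: propyl in place of (2-methoxyethyl)sulfanyl gives a 19-fold lower number from compound 2 to compound 4 (1.29 log units; beyond the scatter) with the rest of the molecule unchanged. The swap removes the sulfur and the oxygen of the side chain together, so this one step cannot separate them. Still open, on these data alone, is how propylsulfanyl, which would keep the sulfur, or a longer chain such as butyl would behave at this carbon. Nothing shown here explains the size of this step.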